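Fluoro for methyl on the phenyl of compound 2

A few compounds are considered here, and "the series" means these few. Any claim that something is new, unique, unknown or untested is made for them only; others in the source may bear on it.

Measured compounds in a functional assay on OVCAR-3 cells (Homo sapiens) for antiproliferative activity, read by MTT assay, with a stated time of 24 h; on this read-out lower numbers stand for stronger inhibition and higher numbers for weaker inhibition:
- compound 1, `O=c1[nH]cc(S(=O)(=O)Nc2ccccc2-c2cn(-c3ccccc3)nn2)c(=O)[nH]1`: 6650 nM
- compound 2, `Cc1cccc(-n2cc(-c3ccccc3NS(=O)(=O)c3c[nH]c(=O)[nH]c3=O)nn2)c1`: 3150 nM
- compound 3, `Cc1ccc(-n2cc(-c3ccccc3NS(=O)(=O)c3c[nH]c(=O)[nH]c3=O)nn2)cc1`: 2190 nM

Compound 2 stands second highest of the three numbers in this assay; its nearest neighbour is compound 3, a difference within the scatter (a 1.4-fold lower number from compound 2 to compound 3 (0.16 log units; within the scatter)), and its furthest is compound 1 (a 2.1-fold lower number from compound 1 to compound 2 (0.32 log units; beyond the scatter)).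

Compound 4, `O=c1[nH]cc(S(=O)(=O)Nc2ccccc2-c2cn(-c3cccc(F)c3)nn2)c(=O)[nH]1`, is not yet measured. It differs from compound 2 by fluoro in place of methyl on an aromatic carbon. For the measured compounds named here, no measured step here swaps methyl for fluoro. Going by the values given here, the only bearing step is the one that introduced this methyl: a 2.1-fold lower number from compound 1 to compound 2 (0.32 log units; beyond the scatter), a modest step beyond the scatter, with the parallel a 3.0-fold lower number from compound 1 to compound 3 (0.48 log units; beyond the scatter) at the other position. Among the compounds with values here, removing the methyl would be expected to give back part of that gap, and the fluoro brings no precedent, so an estimated step of a 1.3-fold higher number from compound 2 to compound 4 (0.12 log units; within the scatter) is expected, at most modest in size and not clearly beyond the scatter. Compound 4 is therefore estimated at 4200 nM in this assay, with a range from 2000 nM to 9000 nM.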

Compound 4, half-maximal inhibitory concentration: > 20000 nM
Compound 4 was reported as a limit (the forecaster's own chance of this, stated with the estimate: 3%); at least 4.7-fold (0.67 log units) between middle value and limit.
By their numbers in this assay, from the lowest: compounds 3 and 2 (each within the scatter of the next); then compound 1. At a limit, above all of these: compound 4.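

In this assay compound 4 is held only as a limit, not a number: the limit of > 20000 nM in this assay, at which 1 of the 4 values shown sits.

The 3-fluorophenyl is not interchangeable with the 3-methylphenyl, as the swap gives an at least 6.3-fold higher number from compound 2 to compound 4 (0.80 log units; beyond the scatter) and the step to the other methyl isomer gives an at least 9.1-fold higher number from compound 3 to compound 4 (0.96 log units; beyond the scatter). Fluoro in place of hydrogen also runs opposite to methyl in place of hydrogen, with an at least 3.0-fold higher number from compound 1 to compound 4 (0.47 log units; beyond the scatter) against a 2.1-fold lower number from compound 1 to compound 2 (0.32 log units; beyond the scatter), so at this position the identity of the substituent decides the direction of the step, and merely filling the position brings no gain.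

The limit leaves the true size of all three new steps open. Whether the loss belongs to fluoro alone or extends to a chloro, a methoxy or an amine in the same place remains unsettled, and the data give no cause for it.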